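This account rests on a few compounds, and the source may have more. Where it says the series, first, only, none or still open, it means among the compounds named here.

In a functional assay on a cell-free system (plasma, Homo sapiens) for inhibition, with Plasma (Rattus norvegicus) as the target (a higher number here means a weaker inhibitor, a lower number a stronger inhibitor), compound 1 (`Cc1c(OCc2ccccc2)ccc2c(N3CCNCC3)cc(=O)oc12`) gives 1100 nM while compound 2 (`CCCOc1ccc2c(N3CCNCC3)cc(=O)oc2c1C`) gives 7770 nM and compound 3 (`COCOc1ccc2c(N3CCNCC3)cc(=O)oc2c1C`) gives 3500 nM as the middle of these three numbers. Compound 4 (`CCOCOc1ccc2c(N3CCNCC3)cc(=O)oc2c1C`) carries one change from compound 3 (methyl in place of hydrogen on a saturated chain carbon bound to an oxygen on a saturated carbon): methyl in place of hydrogen on a saturated chain carbon bound to an oxygen on a saturated carbon, so methoxymethyl becomes ethoxymethyl. Three measured steps exchange other groups in that chain: a 2.2-fold lower number from compound 2 to compound 3 (0.35 log units; beyond the scatter) and a 3.2-fold higher number from compound 1 to compound 3 (0.50 log units; beyond the scatter) and a 7.1-fold higher number from compound 1 to compound 2 (0.85 log units; beyond the scatter) are all modest in size. None of them adds this methyl and they offer no clear direction for it, so no step beyond the scatter is expected. The estimated 1.1-fold lower number from compound 3 to compound 4 (0.03 log units; within the scatter) is therefore small. In this assay compound 4 is expected at 3300 nM with a range from 1500 nM to 7500 nM as the likely span.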

Compound 4, half-maximal inhibitory concentration: 1900 nM
For compound 4 the middle estimate is 1.7-fold (0.24 log units) above the measured one; measured number inside the range.
By their numbers in this assay, from the lowest: compounds 1, 4 and 3 (each within the scatter of the next, the first and the last beyond it); then compound 2.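

In this assay, the methyl that turns methoxymethyl into ethoxymethyl gives a 1.8-fold lower number from compound 3 to compound 4 (0.27 log units; within the scatter), so this extension of the chain causes no change beyond the scatter. Ethoxy in place of phenyl also stays within the scatter, at a 1.7-fold higher number from compound 1 to compound 4 (0.24 log units; within the scatter), whereas ethoxy in place of ethyl gives a 4.1-fold lower number from compound 2 to compound 4 (0.61 log units; beyond the scatter), so a phenyl ring on this chain is not needed to match compound 1. Nothing available explains these differences. On these data alone, how a longer chain, or an amine or carboxylic acid at the end of this chain, would read remains open.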